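Swapping an Aromatic Arm on a Weakly Active Urea

The source may hold more compounds than are shown below. What is called first, only, known or untested is meant among the compounds shown, and "the series" means these compounds.

Three ureas have been tested for their ability to slow the growth of K562 leukaemia cells, in a functional assay on K562 cells (Homo sapiens) for antiproliferative activity, read by MTT assay, with a stated time of 48 h; on this read-out higher numbers stand for weaker inhibition and lower numbers for stronger inhibition. Compound 1 `CN(C)C(=O)N(Cc1cccc([N+](=O)[O-])c1)Cc1ccco1` gives 35400 nM in this assay, compound 3 `CN(C)C(=O)N(Cc1ccco1)Cc1cc(Cl)ccc1O` gives 28600 nM, and compound 2 `CCOC(=O)N1CCC(N(Cc2cccc([N+](=O)[O-])c2)C(=O)N(C)C)CC1` gives 26000 nM. All three numbers sit within the usual scatter of one another, so compound 2 is not separated from the other two.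

Compound 4 `CCOC(=O)N1CCC(N(Cc2cc(Cl)ccc2O)C(=O)N(C)C)CC1` is made from compound 2 by one change: 5-chloro-2-hydroxyphenyl in place of 3-nitrophenyl on a saturated chain carbon bound to an amide-type nitrogen. Compound 1 and compound 3 show the same pair of arms on a different scaffold, and their numbers in this assay fall within the scatter. The step from compound 2 to compound 4 is therefore expected to be a 1.1-fold lower number from compound 2 to compound 4 (0.03 log units; within the scatter), with no real direction. Compound 4 is estimated at 24000 nM, likely between 10000 nM and 60000 nM.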

Compound 4, half-maximal inhibitory concentration: 38400 nM
Estimate against measurement, compound 4: 1.6-fold (0.20 log units) below; measured number inside the range.
By their numbers in this assay, from the lowest: compounds 2, 3, 1 and 4 (each within the scatter of the next).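

In this assay the swap of 3-nitrophenyl for 5-chloro-2-hydroxyphenyl gives a 1.5-fold higher number from compound 2 to compound 4 (0.17 log units; within the scatter) on this core. The two arms therefore cannot be told apart at this place, on a saturated chain carbon bound to an amide-type nitrogen, and this now holds on two different cores. No measurement at hand bears on why they behave alike.

Still open, from the compounds shown here alone, is whether any arm at this place can move the number beyond the scatter. A phenyl ring carrying an amine or a carboxylic acid would be one such test.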